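The source may report more compounds than this note shows. Statements on the series, on what has been measured and on what is new or still open speak of the compounds shown alone.

Among the measured compounds shown here, compound 1, `CNCC1CCCc2cc(S(=O)(=O)c3ccccc3)ccc21`, is the stronger of the two measured members: in an assay on isolated protein for displacement of a labelled ligand from 5-hydroxytryptamine receptor 6 (Homo sapiens) (a higher number here means a weaker inhibitor, a lower number a stronger inhibitor), compound 1 gives 0.316 nM. Compound 2, `CN(C)S(=O)(=O)NC[C@@H]1CCCc2cc(S(=O)(=O)c3cccc(F)c3)ccc21`, carries a dimethylsulfamoyl group on the amine nitrogen and a fluorine on the pendant phenyl ring; in this assay compound 2 gives 2 nM. For the measured compounds named here, compound 2 thus stands at the higher of the two numbers known so far, and its gap to compound 1 lies beyond the usual scatter of the measurement. Going by the values given here, no step between measured compounds has been worked out, so the two values speak only for themselves.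

Compound 3, `O=S(=O)(O)CCCNC[C@@H]1CCCc2cc(S(=O)(=O)c3cccc(F)c3)ccc21`, is not yet measured. It differs from compound 2 in one place: 3-sulfopropyl in place of dimethylsulfamoyl on an amine nitrogen. Among the compounds with values here, nothing among the measured compounds carries a 3-sulfopropyl group, so the step has no direct precedent. Compound 3 is expected to land close to compound 2, with the step of a 1.8-fold higher number from compound 2 to compound 3 (0.24 log units; within the scatter) expected to stay within or only slightly beyond the scatter, in the direction of a weaker inhibitor. In this assay compound 3 is therefore estimated at 3.5 nM, with a likely range from 0.6 nM to 20 nM.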

Compound 3, inhibition constant: 1.26 nM
Estimate against measurement, compound 3: 2.8-fold (0.44 log units) above; the range from low to high includes it.
By their numbers in this assay, from the lowest: compound 1; then compounds 3 and 2 (each within the scatter of the next).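

In this assay, the exchange of dimethylsulfamoyl for 3-sulfopropyl on an amine nitrogen amounts to a 1.6-fold lower number from compound 2 to compound 3 (0.20 log units; within the scatter), so the two groups cannot be told apart in this read-out. Among the compounds shown here, this is the first step that can be read at this position, and it shows that a group with no hydrogen-bond donor and a group with one can sit on this nitrogen without a difference beyond the scatter. No measurement is available that would explain this result.

Compound 1 differs from compound 2 and compound 3 in more than one place, so the gap between its number and theirs cannot be assigned to the group on the nitrogen, to the fluorine on the pendant phenyl ring or to any other single feature. As far as these compounds go, it remains open whether a carboxylic acid in place of 3-sulfopropyl, a longer chain, or a plain secondary amine carrying the same fluorinated phenyl ring would also stay within the scatter of compound 2 and compound 3.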